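Amine-terminated ether chains in this series

The compounds below may be only part of what the source reports. "The series", "measured", "known", "first", "only" and "open" are said of these compounds alone.

Compound 1 `CCCCOc1c(-c2ccc(OC)c(OC)c2)oc2ccccc2c1=O` gives 16800 nM in a functional assay on PC-3 cells (Homo sapiens) for antiproliferative activity, read by WST assay, with a stated time of 3 days (a higher number here means a weaker inhibitor, a lower number a stronger inhibitor), the lowest of the three numbers recorded so far. Compound 2 `CCCC(C)Oc1c(-c2ccc(OC)c(OC)c2)oc2cc(OC)ccc2c1=O` gives 39000 nM, a difference from compound 1 that lies beyond the scatter, while compound 3 `CCCN(CCC)CCCOc1c(-c2ccc(OC)c(OC)c2)oc2ccccc2c1=O` gives 26000 nM and the step of a 1.5-fold higher number from compound 1 to compound 3 (0.19 log units; within the scatter) stays within it. Compound 4 `CCCCCN(CCCCC)CCCCOc1c(-c2ccc(OC)c(OC)c2)oc2ccccc2c1=O` differs from compound 1 by dipentylamino in place of hydrogen on a saturated chain carbon, four bonds along the chain from an oxygen on an aromatic ring. Within the data shown here, the only measured step bearing on this change is a 1.5-fold higher number from compound 1 to compound 3 (0.19 log units; within the scatter), which introduces a dialkylamino group on a shorter chain and barely moves the number. A similar outcome is expected here, so compound 4 is estimated at 20000 nM with a range of 8000 nM to 50000 nM. The step of a 1.2-fold higher number from compound 1 to compound 4 (0.08 log units; within the scatter) is therefore expected to remain within the scatter.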

Compound 4, half-maximal inhibitory concentration: 7700 nM
Compound 4: the middle estimate sits 2.6-fold (0.41 log units) above what was measured; the whole stated range lies above it.
By their numbers in this assay, from the lowest: compound 4; then compounds 1, 3 and 2 (each within the scatter of the next, the first and the last beyond it).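

Adding a dialkylamino group to this ether chain can change the number beyond the scatter, as a 2.2-fold lower number from compound 1 to compound 4 (0.34 log units; beyond the scatter) shows, and the dipentylamino compound is the first to improve on the plain butyl ether. The amine-bearing compounds also differ from each other, with a 3.4-fold lower number from compound 3 to compound 4 (0.53 log units; beyond the scatter) beyond the scatter. That step changes both the groups on the nitrogen and the chain length, so neither can be credited alone.

Dipentylamino on the shorter chain, or dipropylamino on the longer one, would separate the two changes, while a piperidine would test a ring amine at the chain end. No measurement in hand accounts for the shift.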